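This account rests on a few compounds, and the source may have more. Where it says the series, first, only, none or still open, it means among the compounds named here.

Measured compounds:
compound 1, `C=CCn1c(=O)n(C2CCC(CO)C2)c2nc(N)nc(O)c21`, 226 uM in a functional assay (B cells) with Mus musculus as the target; a lower number here means that less compound is needed, a higher number that more compound is needed for the effect
compound 2, `CCOC(=O)Cn1c(=O)n(C2OC(CO)[C@@H](O)[C@H]2O)c2nc(N)nc(O)c21`, 48 uM
compound 3, `C=CCn1c(=S)n(C2OC(COC(C)=O)[C@H]3OC(C)(C)O[C@@H]23)c2nc(N)nc(O)c21`, 50 uM

Among the three numbers, compound 2 has the lowest. Compound 3 sits so close that the two cannot be told apart by this assay alone. Compound 1 is the furthest away, needing clearly more compound than compound 2, a gap that goes beyond the usual scatter.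

The unmeasured compound 4, `Cn1c(=O)n(C2OC(CO)[C@@H](O)[C@H]2O)c2nc(N)nc(O)c21`, shares its sugar-bearing core with compound 2. The change is hydrogen in place of ethoxycarbonyl on a saturated chain carbon bound to an aromatic nitrogen. Among the compounds with values here, no pair of measured compounds differs by this change alone, so nothing in the three measured values fixes its size or direction. Within the data shown here, the one measured compound that carries a small chain on that nitrogen, compound 1, also differs in its ring part, so its higher number cannot be assigned to the chain.

With that uncertainty, a mild step toward a higher number is expected for compound 4, a 1.7-fold higher number from compound 2 to compound 4 (0.22 log units; within the scatter), with a wide range. Compound 4 is estimated at 80 uM, between 25 uM and 250 uM.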

Compound 4, concentration for half-maximal effect: 10 uM
The estimate for compound 4 lay 8.0-fold (0.90 log units) above the measured number, outside the stated range (below it).
By their numbers in this assay, from the lowest: compound 4; then compounds 2 and 3 (each within the scatter of the next); then compound 1.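

In this assay, within the data shown here, the change from (ethoxycarbonyl)methyl to methyl gives a 4.8-fold lower number from compound 2 to compound 4 (0.68 log units; beyond the scatter), the only step in this set that can be read at a single place. It shows that, on this core, the ethoxycarbonyl on a saturated chain carbon bound to an aromatic nitrogen is not required for the effect, since less compound is needed with hydrogen in its place. Nothing shown bears on why the number falls.

The compounds shown leave open whether the step follows from losing the ester alone or from shortening the chain, which a carboxylic acid, an amide or a plain ethyl or longer chain at this place would begin to separate. Going by these compounds, it also remains open whether the same change would give a similar step on the core of compound 1 or the core of compound 3.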